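Swapping Fluoro for Chloro on the Shared Core

The source may hold more compounds than are shown below. What is called first, only, known or untested is meant among the compounds shown, and "the series" means these compounds.

Measured in a functional assay on PSN1 cells (Homo sapiens) for cytotoxicity, read by luminescence, with a stated time of 96 h; on this read-out higher numbers stand for weaker inhibition and lower numbers for stronger inhibition:
Compound 1 `CN1CCN(Cc2ccc(Nc3ncc(F)c(-c4ccc(F)cc4S(=O)(=O)N4CCCC4)n3)cc2)CC1`: "not determined" (no result reported)
Compound 2 `CN1CCN(Cc2ccc(Nc3ncc(Cl)c(Nc4ccccc4S(=O)(=O)N4CCCC4)n3)cc2)CC1`: 2 nM
Compound 3 `CN1CCN(Cc2ccc(Nc3ncc(Cl)c(Nc4ccc(O)cc4S(=O)(=O)N4CCCC4)n3)cc2)CC1`: "not determined" (no result reported)

Compound 1 has no place on the scale of this assay, since no single number was reported for it. Among the compounds with values here, compound 3 also lacks a number, which leaves compound 2 as the only compound with a measured potency. Compound 4 `CN1CCN(Cc2ccc(Nc3ncc(Cl)c(-c4ccc(F)cc4S(=O)(=O)N4CCCC4)n3)cc2)CC1` keeps the structure of compound 1 apart from one atom, with chloro in place of fluoro on an aromatic carbon. Within the data shown here, no measured pair here shows what this swap does, so its size cannot be read from the data. The expected step from compound 1 is none beyond the usual scatter, with no direction favoured. Among the measured compounds shown here, the only numerical guide is compound 2, which gives 2 nM and also carries chloro, but it differs from compound 4 elsewhere, so the expected range stays wide. For compound 4 the estimate is 20 nM, with an expected range from 3 nM to 150 nM.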

Compound 4, half-maximal inhibitory concentration: 192 nM
Estimate against measurement, compound 4: 9.6-fold (0.98 log units) below; measured number outside the range, above it.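

In this assay, within the data shown here, compound 4 gives 192 nM but compound 1 has no single number, so no step from compound 1 to compound 4 can be read. As far as these compounds go, what swapping fluoro for chloro does to potency on this core stays open. No data at hand account for the value of compound 4.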